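A few compounds are considered here, and "the series" means these few. Any claim that something is new, unique, unknown or untested is made for them only; others in the source may bear on it.

Measured in a functional assay on KB cells (Homo sapiens) for antiproliferative activity, read by sulforhodamine B assay, with a stated time of 3 days; on this read-out lower numbers stand for stronger inhibition of growth and higher numbers for weaker inhibition of growth:
- Compound 1 `O=C(Nc1ccc(C(F)(F)F)cc1)c1cccc(Nc2ncc(F)c(Nc3ccc(F)cc3)n2)c1`: > 10000 nM
- Compound 2 `O=C(c1cccc(Nc2ncc(F)c(Nc3ccc(F)cc3)n2)c1)N1CCCCC1`: 14800 nM

The entry for compound 1, > 10000 nM, is a limit and not a number. Within the data shown here, compound 2, at 14800 nM, therefore holds the only true number so far in this assay, and there is no measured number to rank it against.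

The next compound, compound 3 `O=C(Nc1cccc(Nc2ncc(F)c(Nc3ccc(F)cc3)n2)c1)c1ccncc1`, differs from compound 2 in one place: ((pyridin-4-yl)carbonyl)amino in place of (piperidin-1-yl)carbonyl on an aromatic carbon. In words, ((pyridin-4-yl)carbonyl)amino takes the place of (piperidin-1-yl)carbonyl on an aromatic carbon.

Among the measured compounds shown here, only one measured step exists, a step that the limit leaves unreadable from compound 1 to compound 2. It gives no size to carry over, so no change beyond the usual scatter can be forecast in either direction. The expected step is a 1.5-fold lower number from compound 2 to compound 3 (0.17 log units; within the scatter), which is no more than scatter. For compound 3 the estimate is 10000 nM, with an expected range of 3000 nM to 40000 nM.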

Compound 3, concentration for 50% growth inhibition: 5280 nM
The estimate for compound 3 lay 1.9-fold (0.28 log units) above the measured number, within the range that was stated.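

In this assay, among these compounds, this is the first change at this position whose size can be read: a 2.8-fold lower number from compound 2 to compound 3 (0.45 log units; beyond the scatter). The swap alters several things at once: a non-aromatic ring gives way to an aromatic ring with a hetero atom, and the entering group brings a hydrogen-bond donor that the leaving group lacks, so the step cannot be assigned to any one of these features. Compound 1 carries a limit and not a number, so its step to compound 2 cannot be read: the limit of > 10000 nM in this assay, at which 1 of the 3 values shown sits.

Still open, on these data alone, is whether the amide hydrogen or the pyridin-4-yl ring matters more, and how a simple amine or a carboxylic acid on this aromatic carbon would read. As far as these compounds go, whether a step of this size would recur with the rest of the shared core altered also remains open.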